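This account rests on a few compounds, and the source may have more. Where it says the series, first, only, none or still open, it means among the compounds named here.

Compound 1 `CCC(C(=O)N1CCN(c2ccccc2C(F)(F)F)CC1)N1C(=O)CCC1=O`: 0%
Compound 2 `CCC(C(=O)N1CCN(c2cccc(C)c2)CC1)N1C(=O)CCC1=O`: 0%
Compound 3 `CCC(C(=O)N1CCN(c2cccc(F)c2)CC1)N1C(=O)CCC1=O`: 0%

In a functional assay on the whole organism (strain Swiss) with Mus musculus as the target, in the maximal electroshock model, with a stated time of 2 h, at a dose of 300 mg/kg by the intraperitoneal route (on this read-out lower numbers stand for a weaker effect and higher numbers for a stronger effect at the one dose given), compound 3 stands level with compounds 1 and 2, all three giving the same reading. Going by the values given here, the only one-place step among the measured compounds, no change at the digits printed from compound 2 to compound 3 (within the scatter), fluoro in place of methyl on an aromatic carbon, shows no change beyond the scatter. Compound 4 `CCC(C(=O)N1CCN(c2ccccc2Cl)CC1)N1C(=O)CCC1=O` differs from compound 3 by 2-chlorophenyl in place of 3-fluorophenyl on an amine nitrogen in a ring. Among the compounds with values here, no measured step covers this exact change; compound 1 and compound 3 differ in more than one place, and their two values are simply equal. With every reading so far at the same level, the step from compound 3 to compound 4 is expected to show no change beyond the scatter, no change at the digits printed from compound 3 to compound 4 (within the scatter). Compound 4 is therefore expected to give 0%, within a range from 0% to 15%.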

Compound 4, a percentage reported as activity, at one dose (the size of the read-out at that dose, not a potency): 0%
Beside the measured number, compound 4's estimate shows no gap at the digits printed; the range from low to high includes it.
By their numbers in this assay, from the lowest: compounds 1, 2, 3 and 4 (each within the scatter of the next).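

In this assay 2-chlorophenyl in place of 3-fluorophenyl gives no change at the digits printed from compound 3 to compound 4 (within the scatter) and the same group in place of 3-methylphenyl gives no change at the digits printed from compound 2 to compound 4 (within the scatter) on this amine nitrogen in a ring. Chloro in place of trifluoromethyl on an aromatic carbon gives no change at the digits printed from compound 1 to compound 4 (within the scatter) and so adds a chlorine-bearing ring to the aryl groups at this position that all read the same. Nothing available offers an explanation for this sameness. As far as these compounds go, whether an amine or a carboxylic acid on the aromatic ring would change the reading stays open, as does the effect of a longer chain on the shared core.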